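N-Methoxy in place of N-allyl on an aryloxyacetamide

This account rests on a few compounds, and the source may have more. Where it says the series, first, only, none or still open, it means among the compounds named here.

Measured compounds:
compound 1 `O=C(COc1ccc2c(c1)CCC2)N(Cc1cccs1)c1ccn[nH]1` gives 0.001 nM
compound 2 `C=CCN(Cc1cccs1)C(=O)COc1ccc(C)cc1` gives 20 nM
compound 3 `CCN(Cc1cc[nH]c1)C(=O)COc1ccc(C)cc1` gives 21800 nM

All three compounds were tested in an assay on HEK293 cells for agonist activity at transient receptor potential cation channel subfamily M member 8 (Homo sapiens), read by fluorescence and calcium flux, with a stated time of 15 min; on this read-out lower numbers stand for an effect already at smaller amounts and higher numbers for an effect only at larger amounts of compound. In this assay compound 1 gives 0.001 nM, compound 2 gives 20 nM and compound 3 gives 21800 nM. Compound 2 stands second highest of the three numbers; its nearest neighbour is compound 3, which lies far above it, beyond the scatter, and the number of compound 1 lies far below it, also beyond the scatter. Within the data shown here, no two compounds here differ in one place only, so the three values show only that the amide-type nitrogen carries very different groups and that the numbers spread widely with them.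

The untested compound 4 `CON(Cc1cccs1)C(=O)COc1ccc(C)cc1` keeps the core of compound 2 and differs from it in one place: methoxy in place of allyl on an amide-type nitrogen.

Among the measured compounds shown here, since no single-change step is available to anchor the size of this change, the expectation rests on the wide spread seen between compound 2 and its neighbours. Compound 4 is expected to lose some ground in this assay, with the step of a 10-fold higher number from compound 2 to compound 4 (1.00 log units; beyond the scatter) taken as modest but beyond the scatter. Compound 4 is thus estimated at 200 nM, within a range from 20 nM to 2000 nM.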

Compound 4, half-maximal effective concentration: 10 nM
The estimate for compound 4 lay 20-fold (1.30 log units) above the measured number; measured number outside the range, below it.
By their numbers in this assay, from the lowest: compound 1; then compounds 4 and 2 (each within the scatter of the next); then compound 3.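

In this assay, among these compounds, the pair of compound 2 and compound 4 gives the first single-change reading at this position, a 2.0-fold lower number from compound 2 to compound 4 (0.30 log units; within the scatter) for methoxy in place of allyl on an amide-type nitrogen. With the rest of the structure held constant, this exchange removes a double bond outside aromatic rings and brings in a hydrogen-bond acceptor, yet it produces no difference that can be told from the usual scatter, so this nitrogen accepts either group in this one setting without a measurable change in the number. Nothing available explains why these two groups read alike.

What the compounds shown leave open is how far this tolerance reaches: ethoxy, a longer chain, an amine or a carboxylic acid on the same nitrogen could either stay with these two values or depart from them. On these data alone, it is also open whether methoxy in place of allyl would give the same result on another core, since the wide spread among the other compounds involves changes in more than one place and cannot be assigned to this nitrogen alone.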